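The compounds below may be only part of what the source reports. "The series", "measured", "known", "first", "only" and "open" are said of these compounds alone.

In an assay for inhibition of acetolactate synthase (Nicotiana tabacum) (a lower number here means a stronger inhibitor, a higher number a weaker inhibitor), compound 2 `Cc1cc(C)n2nc(S(=O)(=O)Nc3c(Br)ccc4cccnc34)nc2n1` gives 8.7 nM, the lowest of the two numbers measured here, and compound 1 `Cc1ccn2nc(S(=O)(=O)Nc3c(Cl)ccc4cccnc34)nc2n1` gives 37.2 nM in this assay, a gap that lies beyond the usual scatter. Compound 3 `Cc1cc(C)n2nc(S(=O)(=O)Nc3c(Cl)ccc4cccnc34)nc2n1` differs from compound 2 by chloro in place of bromo on an aromatic carbon. Among the measured compounds shown here, no single step between measured compounds isolates this exchange, since compound 1 differs from compound 2 in two places at once. The step expected from compound 2 to compound 3 in this assay, a 1.4-fold higher number from compound 2 to compound 3 (0.14 log units; within the scatter), is small, likely within the scatter. For compound 3 the expected value in this assay is 12 nM, with a range from 5 nM to 30 nM.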

Compound 3, half-maximal inhibitory concentration: 9.4 nM
Compound 3: middle estimate off by 1.3-fold (0.11 log units), on the high side, within the range that was stated.
By their numbers in this assay, from the lowest: compounds 2 and 3 (each within the scatter of the next); then compound 1.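

In this assay chloro and bromo on this aromatic carbon give numbers that cannot be told apart (a 1.1-fold higher number from compound 2 to compound 3 (0.03 log units; within the scatter)), so swapping one halogen for the other changes nothing measurable here. The one-place change that does register is methyl in place of hydrogen on an aromatic carbon of the shared core (a 4.0-fold lower number from compound 1 to compound 3 (0.60 log units; beyond the scatter)), a step beyond the scatter. Nothing available explains either result. Still open, as far as these compounds go, is whether an amine or a methoxy group in place of the halogen would keep the number this low.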